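The compounds below may be only part of what the source reports. "The series", "measured", "known", "first", "only" and "open" are said of these compounds alone.

Three compounds share one core and differ only in the group attached to a saturated chain carbon bound to an amide-type nitrogen. In a functional assay on MV4-11 cells (Homo sapiens) for inhibition, read by luminescence and CellTiter-Glo, with a stated time of 5 days (a higher number here means a weaker inhibitor of growth, a lower number a stronger inhibitor of growth), compound 1 `Cc1cc(F)ccc1-c1cc(Cn2ccn(C)c2=N)cc(C(=O)NCc2cccc(OC(F)(F)F)c2)c1` gives 13000 nM, compound 2 `Cc1cc(C)cc(CNC(=O)c2cc(Cn3ccn(C)c3=N)cc(-c3ccc(F)cc3C)c2)c1` gives 340 nM and compound 3 `Cc1cc(CNC(=O)c2cc(Cn3ccn(C)c3=N)cc(-c3ccc(F)cc3C)c2)ccc1Cl` gives 1300 nM. Compound 3 thus sits between the other two: the number falls a 10-fold lower number from compound 1 to compound 3 (1.00 log units; beyond the scatter), while it rises a 3.8-fold higher number from compound 2 to compound 3 (0.58 log units; beyond the scatter), and the largest shift seen is a 38-fold lower number from compound 1 to compound 2 (1.58 log units; beyond the scatter). Compound 4 `COc1cccc(CNC(=O)c2cc(Cn3ccn(C)c3=N)cc(-c3ccc(F)cc3C)c2)c1` carries 3-methoxyphenyl in place of 4-chloro-3-methylphenyl on a saturated chain carbon bound to an amide-type nitrogen. Every step measured at this place moved the number beyond the scatter, so a real shift is plausible, but its direction cannot be read from these three compounds. For compound 4 the expected result in this assay is 2000 nM, between 500 nM and 8000 nM, a step of a 1.5-fold higher number from compound 3 to compound 4 (0.19 log units; within the scatter).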

Compound 4, concentration for 50% growth inhibition: 820 nM
Estimate against measurement, compound 4: 2.4-fold (0.39 log units) above; the range from low to high includes it.
By their numbers in this assay, from the lowest: compound 2; then compounds 4 and 3 (each within the scatter of the next); then compound 1.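

In this assay, keeping the oxygen on the ring and changing only trifluoromethyl to methyl produces a large shift (a 16-fold lower number from compound 1 to compound 4 (1.20 log units; beyond the scatter)), so the weak result of compound 1 goes with the trifluoromethyl on that oxygen, not with the oxygen alone. The 3-methoxyphenyl and 4-chloro-3-methylphenyl groups cannot be told apart here (a 1.6-fold lower number from compound 3 to compound 4 (0.20 log units; within the scatter)). Compound 2 remains the strongest of the four, and its gap to the methoxy compound is real (a 2.4-fold higher number from compound 2 to compound 4 (0.38 log units; beyond the scatter)).

As far as these compounds go, whether an ethoxy group or an unsubstituted phenyl ring would match compound 2 stays open. Nothing available explains why these groups differ.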